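The source may report more compounds than this note shows. Statements on the series, on what has been measured and on what is new or still open speak of the compounds shown alone.

Working notes on the series, all values from a functional assay, read by Griess assay, with a stated time of 2.5 h; a higher number here means a weaker inhibitor, a lower number a stronger inhibitor:

- compound 1 `COc1cc(OC)c(-c2cc(=O)c3ccc(O)cc3o2)cc1OC`: 2.27 ug/mL
- compound 2 `COc1cc(OC)c(OC)cc1/C=C/C(=O)c1ccc(-c2c[nH]cn2)cc1`: 1.97 ug/mL
- compound 3 `COc1cc(OC)c(-c2cc(=O)c3cc(Cl)ccc3o2)cc1OC`: 2.15 ug/mL

In this assay compound 2 gives 1.97 ug/mL, which lies within the scatter of both compound 1 and compound 3. On these numbers alone, compound 2 cannot be separated from either of them.

The next compound to be read is compound 4 `COc1cc(OC)c(OC)cc1/C=C/C(=O)c1ccc(O)cc1`, which differs from compound 2 in one place: hydroxy in place of 1H-imidazol-4-yl on an aromatic carbon. Hydroxy stands in place of 1H-imidazol-4-yl on an aromatic carbon of a six-membered aromatic ring of carbon only, para to a large group.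

Within the data shown here, no two measured compounds differ in a single place, so the series offers no measured step to carry across to this change. Among the measured compounds shown here, the only guide is the narrow spread of the values so far. Compound 1 also bears a hydroxy group and gives 2.27 ug/mL, although it differs from compound 4 in more than this one place. No shift beyond the scatter is therefore expected in this assay. The expected change is a 1.3-fold higher number from compound 2 to compound 4 (0.10 log units; within the scatter), which would leave the two compounds indistinguishable. For compound 4 the estimated value is 2.5 ug/mL, with an expected range of 1 ug/mL to 6 ug/mL.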

Compound 4, half-maximal inhibitory concentration: 2.5 ug/mL
Compound 4: the middle estimate sits on the measured number at the digits printed; measured number inside the range.
By their numbers in this assay, from the lowest: compounds 2, 3, 1 and 4 (each within the scatter of the next).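

In this assay the series now has its first comparison in a single place, a 1.3-fold higher number from compound 2 to compound 4 (0.10 log units; within the scatter) for hydroxy in place of 1H-imidazol-4-yl on an aromatic carbon, para to a large group. At this position on the six-membered aromatic ring of carbon only, a five-membered aromatic ring of 5 heavy atoms can thus be replaced by a group of 1 heavy atom with no shift that can be told from the scatter, so in this pair the read-out does not depend on keeping the ring. Nothing measured here bears on why the two compounds read alike.

Both groups in this step carry 1 hydrogen-bond donor and 1 hydrogen-bond acceptor, so the compounds shown leave open whether methoxy or methyl, an amine or a carboxylic acid at the same position would also stay within the scatter. Also open is whether any single change on this shared core can move the number beyond the scatter, as each compound shown lies within the scatter of the next.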